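The source may hold more compounds than are shown below. What is called first, only, known or untested is meant among the compounds shown, and "the series" means these compounds.

Measured in an ADME assay on Raji cells (Homo sapiens) for cytotoxicity, with a stated time of 72 h; a lower number here means that less compound is needed, a higher number that more compound is needed for the effect:

- compound 1 `Cc1cc(NC(=O)Nc2ccc(C)c(Cl)c2)c2ccccc2n1`: > 25000 nM
- compound 2 `Cc1cc(NC(=O)Nc2ccccc2N)c2ccccc2n1`: > 25000 nM
- compound 3 `Cc1ccc(NC(=O)Nc2cc(C)nc3ccccc23)cc1`: > 25000 nM

Each of these entries is a limit of the assay, not a number. Compound 3 gives > 25000 nM, which is likewise only a limit. It therefore cannot be ranked against compound 1 or compound 2.

Compound 4 `Cc1cc(NC(=O)Nc2ccc(SC(F)(F)F)cc2)c2ccccc2n1` differs from compound 3 in one place: (trifluoromethyl)sulfanyl in place of methyl on an aromatic carbon. Here (trifluoromethyl)sulfanyl stands in place of methyl on an aromatic carbon, para to a large group.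

Two measured steps lead to compound 3: a step that the two limits leave unreadable from compound 1 to compound 3 and a step that the two limits leave unreadable from compound 2 to compound 3. Neither has a readable size, so neither offers a size or direction to carry over. The expectation rests instead on the limit of > 25000 nM in this assay, at which 3 of the 3 values shown sit: compound 4 is expected to stay close to it, with no step beyond the scatter, although a true number could still appear. The estimated step is a number no higher from compound 3 to compound 4 (the limit leaves the size open). For compound 4, the estimate is 25000 nM, with an expected range from 8000 nM to 50000 nM.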

Compound 4, half-maximal effective concentration: 10000 nM
Beside the measured number, compound 4's estimate is 2.5-fold (0.40 log units) above it, and the stated range covers the measured number.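

In this assay, replacing methyl with (trifluoromethyl)sulfanyl on this aromatic carbon, para to a large group, gives an at least 2.5-fold lower number from compound 3 to compound 4 (0.39 log units; beyond the scatter), so this position can respond to a change of group. The earlier compounds shown here could not show this, as their entries offered no readable step: the limit of > 25000 nM in this assay, at which 3 of the 4 values shown sit. Going by these compounds alone, compound 4 therefore gives this small set its only true number, and the change behind it swaps a group of one heavy atom for one of five, with one hydrogen-bond acceptor added.

This single step cannot separate the part played by the sulfur from that of the fluorine atoms, and a methylsulfanyl or a trifluoromethyl group on the same carbon would help to tell them apart. Going by these compounds, how large the step truly is also stays open, given that compound 3 has only a limit.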